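Swapping a Phenyl Group for an Undecyl Chain

The source may report more compounds than this note shows. Statements on the series, on what has been measured and on what is new or still open speak of the compounds shown alone.

In an ADME assay on HII4E cells (Mus musculus) for cytotoxicity, read by MTT assay, with a stated time of 48 h (on this read-out higher numbers stand for weaker inhibition and lower numbers for stronger inhibition), compound 2 `CC(=O)OC[C@@H]1C=C(OC(C)=O)C(=O)[C@@H](OCC(=O)NCc2ccccc2)O1` gives 163 ug/mL, while compound 1 `C#CCNC(=O)CO[C@H]1O[C@H](COC(C)=O)C=C(OC(C)=O)C1=O` gives 282 ug/mL. Among the compounds with values here, these are the only two numbers so far, and they lie within the usual scatter of each other. The next molecule is compound 3 `CCCCCCCCCCCCNC(=O)CO[C@H]1O[C@H](COC(C)=O)C=C(OC(C)=O)C1=O`, which has one change from compound 2: undecyl in place of phenyl on a saturated chain carbon bound to an amide-type nitrogen. Within the data shown here, one measured step bears on this position, the exchange of ethynyl for phenyl: a 1.7-fold lower number from compound 1 to compound 2 (0.24 log units; within the scatter). Among the measured compounds shown here, that step stayed within the scatter and involved no long chain, so it is a weak guide, and no measured compound carries undecyl. The estimate therefore starts from compound 2 at 163 ug/mL. The expected step in this assay is small, leaning toward a lower number: a 1.5-fold lower number from compound 2 to compound 3 (0.17 log units; within the scatter). For compound 3 the estimated value is 110 ug/mL, with an expected range from 35 ug/mL to 280 ug/mL.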

Compound 3, half-maximal inhibitory concentration: 136 ug/mL
Beside the measured number, compound 3's estimate is 1.2-fold (0.09 log units) below it; low and high end bracket the measured number.
By their numbers in this assay, from the lowest: compounds 3, 2 and 1 (each within the scatter of the next, the first and the last beyond it).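

In this assay, a long chain with no ring is tolerated at this position, on a saturated chain carbon bound to an amide-type nitrogen: exchanging phenyl for undecyl gives a 1.2-fold lower number from compound 2 to compound 3 (0.08 log units; within the scatter), so among these compounds the aromatic ring of phenyl is not required to hold the number at this level. Within the data shown here, exchanging ethynyl for undecyl gives a 2.1-fold lower number from compound 1 to compound 3 (0.32 log units; beyond the scatter), the only step at this position so far to pass beyond the scatter, and only modestly. No measurement shown here explains why these numbers fall where they do.

On these data alone, it remains open whether an amine or a carboxylic acid at this position would shift the number more clearly. As far as these compounds go, it is equally open whether a chain longer than undecyl would extend the small difference from ethynyl or leave it unchanged.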